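Benzimidazole demethylation on a spiro-lactam pyrrolopyridine series

The source may hold more compounds than are shown below. What is called first, only, known or untested is meant among the compounds shown, and "the series" means these compounds.

Compound 1, `Cn1ncc2cc(-c3cnc4[nH]ncc4c3N3CCC4(CCNC4=O)CC3)ccc21`: in an assay on cells for binding affinity to Cyclin-C/Cyclin-dependent kinase 19 (Homo sapiens), read by LanthaScreen (a lower number here means a stronger inhibitor, a higher number a weaker inhibitor), compound 1 gives 214 nM.
Compound 2, `Cn1cnc2ccc(-c3cnc4[nH]ccc4c3N3CCC4(CCNC4=O)CC3)cc21`: in this assay compound 2 gives 11 nM.

Compound 2 holds the lowest of the two numbers measured in this assay; its nearest neighbour, compound 1, sits at a value beyond the usual scatter, so on the numbers shown compound 2 is the stronger of the two. Compound 1 and compound 2 differ in more than one place, so their gap cannot be tied to any single change.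

Compound 3, `O=C1NCCC12CCN(c1c(-c3ccc4[nH]cnc4c3)cnc3[nH]ccc13)CC2`, has not yet been measured. It differs from compound 2 in one place: 1H-benzimidazol-5-yl in place of 1-methyl-1H-benzimidazol-6-yl on an aromatic carbon. The leaving group carries no hydrogen-bond donor, the entering group one, while one hydrogen-bond acceptor is lost. Within the data shown here, no measured pair in this set isolates such a change, so the direction is uncertain; a step of modest size, within or only slightly beyond the scatter, is expected from compound 2, as a 1.4-fold higher number from compound 2 to compound 3 (0.13 log units; within the scatter). Compound 3 is therefore estimated at 15 nM in this assay, with a range from 5 nM to 50 nM.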

Compound 3, half-maximal inhibitory concentration: 17 nM
Compound 3: middle estimate off by 1.1-fold (0.05 log units), on the low side; measured number inside the range.
By their numbers in this assay, from the lowest: compounds 2 and 3 (each within the scatter of the next); then compound 1.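

Among these compounds, compound 2 and compound 3 are the first pair in this set that differ in one place, so this aromatic carbon, ortho to a large group and two atoms from the ring nitrogen, can now be read on its own. In this assay, 1H-benzimidazol-5-yl in place of 1-methyl-1H-benzimidazol-6-yl gives a 1.5-fold higher number from compound 2 to compound 3 (0.19 log units; within the scatter), so the two groups cannot be told apart on these numbers, even though the entering group has one heavy atom fewer, a hydrogen-bond donor that the leaving group lacks, and one hydrogen-bond acceptor fewer. No supporting evidence on this result is available to explain it.

The gap to compound 1, which differs from both in more than one place, still cannot be tied to any single change, and this one step does not separate the methyl group from the point of attachment of the benzimidazole. It also leaves open how the number would respond to an ethyl group or a longer chain on the benzimidazole nitrogen, or to a primary amine or a carboxylic acid on its carbon ring.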